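A few compounds are considered here, and "the series" means these few. Any claim that something is new, unique, unknown or untested is made for them only; others in the source may bear on it.

Measured compounds:
compound 1, `CS(=O)(=O)c1cc(C(=O)N=C(N)N)c(Cl)cc1Cl`: 140 nM
compound 2, `Cc1c(C(=O)N=C(N)N)cc(S(C)(=O)=O)c(Cl)c1Cl`: 29 nM
compound 3, `Cc1cc(SC(C)(C)C)c(S(C)(=O)=O)cc1C(=O)N=C(N)N`: 22 nM

In a functional assay for inhibition of sodium/hydrogen exchanger (Oryctolagus cuniculus) (a lower number here means a stronger inhibitor, a higher number a weaker inhibitor), compound 3 gives the lowest of the three numbers, yet its gap to compound 2 is within the usual scatter of this assay, so the two cannot be set in order. Compound 1 stands apart from compound 3, with a gap that is beyond the scatter.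

Compound 4, `Cc1cc(-n2ccnc2)c(S(C)(=O)=O)cc1C(=O)N=C(N)N`, has not yet been measured. It differs from compound 3 in one place: 1H-imidazol-1-yl in place of (tert-butyl)sulfanyl on an aromatic carbon

Going by the values given here, no step between two measured compounds touches this position, so there is nothing in the measured numbers to lean on for the size or direction of the change. Because compound 3 gives 22 nM in this assay, and because compound 2 with a different pattern of groups gives 29 nM, a value within the scatter of it, the core appears to tolerate variation. Compound 4 is expected to show a modest step towards a higher number, a 2.3-fold higher number from compound 3 to compound 4 (0.36 log units; beyond the scatter), though a step within the scatter would not surprise. Compound 4 is thus estimated at 50 nM, with a range from 15 nM to 200 nM.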

Compound 4, half-maximal inhibitory concentration: 23 nM
Beside the measured number, compound 4's estimate is 2.2-fold (0.34 log units) above it; low and high end bracket the measured number.
By their numbers in this assay, from the lowest: compounds 3, 4 and 2 (each within the scatter of the next); then compound 1.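

In this assay, placing 1H-imidazol-1-yl in place of (tert-butyl)sulfanyl on this aromatic carbon gives a 1.0-fold higher number from compound 3 to compound 4 (0.02 log units; within the scatter), a step within the scatter. This position, ortho to the methylsulfonyl group, thus carries two unlike groups, one with no ring and one a five-membered aromatic ring with 2 hetero atoms, with no difference that this assay can read. Nothing measured here speaks to the reason for this sameness.

From the compounds shown here alone, whether an amine, a carboxylic acid or a longer chain such as n-butylsulfanyl on this carbon would also leave the number within the scatter remains open. So does the outcome for a much smaller group, such as methoxy or a single fluorine atom, in the same place.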